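The compounds below may be only part of what the source reports. "The series", "measured", "known", "first", "only" and "open" are said of these compounds alone.

Measured so far:
- compound 1, `CCCCc1ccc(COC(=O)N[C@H]2CNC2=O)cc1`: 23 nM
- compound 2, `CC(C)(C)c1ccc(COC(=O)N[C@H]2CNC2=O)cc1`: 310 nM
- compound 3, `CCCCCCCCOC(=O)N[C@H]1CNC1=O`: 37 nM

In an assay on HEK293 cells for inhibition of N-acylethanolamine-hydrolyzing acid amidase (Homo sapiens), read by fluorescence, with stated times of 10 min and 50 min (a lower number here means a stronger inhibitor, a higher number a weaker inhibitor), compound 1 has the lowest number of the three. Compound 3 sits within the scatter of it, so the two cannot be told apart; compound 2 lies clearly higher, as the step of a 13-fold higher number from compound 1 to compound 2 (1.13 log units; beyond the scatter) shows. Compound 4, `O=C(N[C@H]1CNC1=O)OCc1ccc(-c2ccccc2)cc1`, is not yet measured. It differs from compound 1 in one place: phenyl in place of butyl on an aromatic carbon. Among the compounds with values here, only one measured step touches the same position, the replacement of butyl by tert-butyl, which gave a 13-fold higher number from compound 1 to compound 2 (1.13 log units; beyond the scatter) — a large loss. A phenyl is a different kind of group from a branched chain, so that step is a loose guide at best. A modest rise, weaker than from compound 1 to compound 2, is expected, namely a 2.6-fold higher number from compound 1 to compound 4 (0.42 log units; beyond the scatter). Compound 4 is therefore estimated at 60 nM in this assay, with a likely range from 20 nM to 250 nM.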

Compound 4, half-maximal inhibitory concentration: 513 nM
Compound 4: the middle estimate sits 8.6-fold (0.93 log units) below what was measured; the measured number lies above the stated range.
By their numbers in this assay, from the lowest: compounds 1 and 3 (each within the scatter of the next); then compounds 2 and 4 (each within the scatter of the next).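

In this assay, the large loss at this position is not confined to tert-butyl: phenyl in place of butyl also costs a great deal, with a 22-fold higher number from compound 1 to compound 4 (1.35 log units; beyond the scatter). Phenyl and tert-butyl cannot be told apart, with a 1.7-fold higher number from compound 2 to compound 4 (0.22 log units; within the scatter), so among the three groups at this aromatic carbon, only butyl gives a low number. Nothing available here explains this difference. The compounds shown leave open whether a shorter propyl chain, a longer hexyl chain or a cyclohexyl group would keep the number near that of butyl.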